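Removing a Bromo Group From a Shared Core

This account rests on a few compounds, and the source may have more. Where it says the series, first, only, none or still open, it means among the compounds named here.

In a functional assay on MDA-MB-231 cells (Homo sapiens) for cytotoxicity, read by MTT assay, with a stated time of 24 h (on this read-out lower numbers stand for stronger inhibition and higher numbers for weaker inhibition), compound 1 `Cc1cc(O)c(C(=O)/C=C/c2ccc(OCc3ccccc3)cc2)c(-c2ccccc2)c1C(=O)/C=C/c1ccc(OCc2ccccc2)cc1` gives 10000 nM. In the same test compound 2 `Cc1cc(O)c(C(=O)/C=C/c2ccc(OCc3ccccc3)cc2)c(-c2ccc(Br)cc2)c1C(=O)/C=C/c1ccc(OCc2ccccc2)cc1` gives 20000 nM, and compound 3 `Cc1cc(O)c(C(=O)/C=C/c2ccc(F)cc2)c(-c2ccc(Br)cc2)c1C(=O)/C=C/c1ccc(F)cc1` gives 22300 nM.

Compound 1 and compound 2 share one core and differ in a single place: hydrogen in place of bromo on an aromatic carbon. On this read-out that change made a 2.0-fold lower number from compound 2 to compound 1 (0.30 log units; within the scatter), a step that is within the usual scatter of repeated measurements, so the two numbers cannot be told apart with confidence.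

Compound 3 carries the same bromo group, but on a different core; the difference between the two cores is not broken down here. Compound 3 has the highest number of the three, yet its value and that of compound 2 lie within the scatter of each other, while the gap to compound 1 lies beyond it.

Compound 4 `Cc1cc(O)c(C(=O)/C=C/c2ccc(F)cc2)c(-c2ccccc2)c1C(=O)/C=C/c1ccc(F)cc1` has not yet been measured. Among the measured compounds shown here, it differs from compound 3 by hydrogen in place of bromo on an aromatic carbon, which is the same change as the one from compound 2 to compound 1, placed in the same way on the ring. For the measured compounds named here, only one measured example of this change exists, and it rests on that alone, because that example gave a 2.0-fold lower number from compound 2 to compound 1 (0.30 log units; within the scatter). A step of similar size is expected in this assay, namely a 1.9-fold lower number from compound 3 to compound 4 (0.27 log units; within the scatter). Compound 4 is therefore estimated at 12000 nM in this assay, most likely between 5000 nM and 30000 nM.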

Compound 4, half-maximal inhibitory concentration: 20000 nM
Beside the measured number, compound 4's estimate is 1.7-fold (0.22 log units) below it, and the stated range covers the measured number.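

In this assay, replacing bromo with hydrogen on the second core gives a 1.1-fold lower number from compound 3 to compound 4 (0.05 log units; within the scatter), so the 4-bromophenyl and phenyl forms of that core cannot be told apart on this read-out. Set side by side, the two examples of the change do not differ by more than repeated measurements would be expected to: the same change on two cores in this assay, a 2.0-fold lower number (0.30 log units; within the scatter) from compound 2 to compound 1 and a 1.1-fold lower number (0.05 log units; within the scatter) from compound 3 to compound 4, 1.8-fold (0.25 log units) apart, within the scatter of two such steps. This shows that, so far, the change has behaved alike on both cores, but each step is itself within the scatter, so the agreement may only mean that the change has little or no measurable effect on either core, and it does not show that bromo matters for cytotoxicity or that the step would carry over to further cores in the series.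

The compounds shown leave open whether a different group at this place on the ring, such as an amine, a carboxylic acid or a longer chain, would shift the number by a step that stands clear of the scatter. They also leave open how the change from bromo to hydrogen would read on any core beyond these two, or in any other cell line.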